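The source may hold more compounds than are shown below. What is called first, only, known or untested is meant among the compounds shown, and "the series" means these compounds.

Compound 1 `C#CCSc1nc(Nc2ccc(Cl)cc2)c(C#N)c(-c2ccccc2)n1` and compound 2 `C#CCSc1nc(Nc2cccc(Cl)c2)c(C#N)c(-c2ccccc2)n1` share one core; compound 3 `N#Cc1c(Nc2ccc(Cl)cc2)nc(SCc2cn(Cc3ccccc3Cl)nn2)nc1-c1ccccc1` and the still unmeasured compound 4 `N#Cc1c(Nc2cccc(Cl)c2)nc(SCc2cn(Cc3ccccc3Cl)nn2)nc1-c1ccccc1` share another, and the difference between the two cores is not broken down here. In a functional assay on ECa-109 cells (Homo sapiens) for inhibition, read by MTT assay, with a stated time of 72 h (on this read-out higher numbers stand for weaker inhibition and lower numbers for stronger inhibition), compound 1 gives > 128000 nM, which is a limit of the assay and not a number. In this assay compound 2 likewise gives > 128000 nM, again a limit. The change from compound 1 to compound 2 is 3-chlorophenyl in place of 4-chlorophenyl on a nitrogen on an aromatic ring, and the step it made is a step that the two limits leave unreadable from compound 1 to compound 2, because the limit of > 128000 nM in this assay, at which 2 of the 3 values shown sit, caps both values. For the measured compounds named here, compound 3 stands apart, since in this assay compound 3 gives 1420 nM, the only plain number among the three.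

Compound 4 carries the same change relative to compound 3, namely (3-chlorophenyl in place of 4-chlorophenyl on a nitrogen on an aromatic ring). With the earlier step unreadable, the expectation for compound 4 can rest only on the value of compound 3, 1420 nM, and the step from compound 3 to compound 4 is expected to be roughly a 1.1-fold higher number from compound 3 to compound 4 (0.05 log units; within the scatter). Compound 4 is therefore estimated to give about 1600 nM in this assay, likely between 450 nM and 6000 nM.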

Compound 4, half-maximal inhibitory concentration: 24400 nM
For compound 4 the middle estimate is 15-fold (1.18 log units) below the measured one, and the stated range ends below it.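

On the second core, putting 3-chlorophenyl in place of 4-chlorophenyl on the nitrogen gives, in this assay, a 17-fold higher number from compound 3 to compound 4 (1.24 log units; beyond the scatter), a clear weakening of inhibition. So two compounds with the same atoms, joined differently, can behave very differently here, though this rests on a single pair and sets no general rule. It does not show whether the change carries over from one core to the other, because compound 1 and compound 2 both give values that are limits of the assay and not numbers, so the step on the first core cannot be read: the limit of > 128000 nM in this assay, at which 2 of the 4 values shown sit.

Why the change costs so much on the second core remains open, since nothing shown explains the step. Also open, as far as these compounds go, is whether the same sensitivity would appear with an amine or a methoxy group in place of the chlorine on that phenyl ring.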